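Cytotoxicity notes: extending the side-chain amide of compound 1

A few compounds are considered here, and "the series" means these few. Any claim that something is new, unique, unknown or untested is made for them only; others in the source may bear on it.

Compound 1 `Cc1cc(C)cc(S(=O)(=O)c2c(C(=O)NCc3n[nH]c4ccccc34)[nH]c3ccc(Cl)cc23)c1` is the starting point of this comparison. In an ADME assay on MT4 cells (Homo sapiens) for cytotoxicity, read by MTT assay (on this read-out lower numbers stand for higher toxicity in this test and higher numbers for lower toxicity in this test), compound 1 gives only > 50700 nM, which is a limit of the assay and not a measured number. Compound 2 `Cc1cc(C)cc(S(=O)(=O)c2c(C(=O)NCC(=O)NC(C)c3ccccc3F)[nH]c3ccc(Cl)cc23)c1` gives 23000 nM in this assay, and compound 3 `Cc1cc(C)cc(S(=O)(=O)c2c(C(=O)NCC(=O)NCCn3c(C)cnc3[N+](=O)[O-])[nH]c3ccc(Cl)cc23)c1` gives 24500 nM.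

For the measured compounds named here, two measured steps bear on the change under study. The first, an at least 2.2-fold lower number from compound 1 to compound 2 (0.34 log units; beyond the scatter), shows that replacing the fused bicyclic group on the chain by a second amide bearing an aromatic terminus moves the number down, though only a bound can be given because compound 1 sits at the limit of > 50700 nM in this assay, at which 1 of the 3 values shown sits. The second, a 1.1-fold higher number from compound 2 to compound 3 (0.03 log units; within the scatter), shows that exchanging the aromatic terminus of that second amide for a different one leaves the number where it was.

Compound 4 `Cc1cc(C)cc(S(=O)(=O)c2c(C(=O)NC(C)C(=O)NCc3ccncn3)[nH]c3ccc(Cl)cc23)c1` differs from compound 1 by a group of 12 heavy atoms (8 carbon, 3 nitrogen, 1 oxygen; one six-membered aromatic ring with 2 hetero atoms) in place of a group of 10 heavy atoms (8 carbon, 2 nitrogen; one five-membered aromatic ring with 2 hetero atoms, one six-membered aromatic ring of carbon only), on an amide-type nitrogen. Like compound 2 and compound 3, compound 4 carries a second amide in the chain and an aromatic terminus on its nitrogen, so a step of the same kind as that from compound 1 to compound 2 is expected, downward, of at least modest size. The expected step is an at least 2.0-fold lower number from compound 1 to compound 4 (0.30 log units; that floor lies within the scatter). Compound 4 is therefore estimated at 25000 nM, with a range from 12000 nM to 55000 nM.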

Compound 4, half-maximal cytotoxic concentration: 28100 nM
Beside the measured number, compound 4's estimate is 1.1-fold (0.05 log units) below it; low and high end bracket the measured number.
By their numbers in this assay, from the lowest: compounds 2, 3 and 4 (each within the scatter of the next). At a limit, above all of these: compound 1.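

In this assay, the exchange of (1H-indazol-3-yl)methyl on the amide-type nitrogen for the group of 12 heavy atoms in compound 4 gives an at least 1.8-fold lower number from compound 1 to compound 4 (0.25 log units; that floor lies within the scatter), so this floor does not by itself establish a change beyond the scatter. Compound 4 adds a third terminus to the series, a six-membered aromatic ring with 2 hetero atoms, and compounds 2, 3 and 4 each lie within the scatter of the next, so across these three compounds the kind of aromatic ring on the second amide has shown no separable effect on the number. The true size of the step stays unknown because compound 1 stands at a limit and not at a measured number: the limit of > 50700 nM in this assay, at which 1 of the 4 values shown sits.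

From the compounds shown here alone, whether a terminus without an aromatic ring, such as a primary amine or a carboxylic acid, would keep the number with compounds 2, 3 and 4 remains open. Also open is how a longer chain between the two amides would read in this assay, since the compounds shown do not separate the length of the chain from the identity of its terminus.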